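This account rests on a few compounds, and the source may have more. Where it says the series, first, only, none or still open, it means among the compounds named here.

Measured in a functional assay on MT4 cells (Homo sapiens) for cytotoxicity; on this read-out higher numbers stand for lower toxicity in this test and lower numbers for higher toxicity in this test:
- compound 1 `CCC(c1ccccc1)c1cc(O)nc(SC2CCCCC2)n1`: 51000 nM
- compound 2 `CCC(c1cc(O)nc(SC2CCCCC2)n1)c1c(Cl)cccc1Cl`: 200000 nM
- compound 3 `CCC(c1cc(O)nc(SC(C)C)n1)c1c(F)cccc1F`: 130000 nM

Compound 3 (130000 nM) cannot be told apart from compound 2 (200000 nM), since the two lie within the scatter. Compound 1 (51000 nM) lies lower, beyond the scatter. Compound 4 `CCC(c1cc(O)nc(SC2CCCCC2)n1)c1c(F)cccc1F` has cyclohexyl in place of isopropyl on a sulfur. Among the measured compounds shown here, the one measured step, a 3.9-fold higher number from compound 1 to compound 2 (0.59 log units; beyond the scatter), is modest, but it sits elsewhere and has cyclohexyl on both sides. For the measured compounds named here, no measured step tests this swap directly, so no change beyond the scatter is expected in this assay. The expected step is a 1.2-fold lower number from compound 3 to compound 4 (0.07 log units; within the scatter). For compound 4 the estimated value is 110000 nM, with an expected range from 45000 nM to 260000 nM.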

Compound 4, half-maximal cytotoxic concentration: > 200000 nM
Compound 4 gave a limit, no number (the forecaster's own chance of this, stated with the estimate: 20%); middle value at least 1.8-fold (0.25 log units) away from the limit.
By their numbers in this assay, from the lowest: compound 1; then compounds 3 and 2 (each within the scatter of the next).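

Compound 4 gave a limit of the assay, not a number: the limit of > 200000 nM in this assay, at which 1 of the 4 values shown sits. Cyclohexyl in place of isopropyl on the sulfur therefore did not lower the number, with an at least 1.5-fold higher number from compound 3 to compound 4 (0.18 log units; that floor lies within the scatter), so this larger group brought no sign of added toxicity in this test. With cyclohexyl on both sides, 2,6-difluorophenyl in place of phenyl gives an at least 3.9-fold higher number from compound 1 to compound 4 (0.59 log units; beyond the scatter), while 2,6-difluorophenyl in place of 2,6-dichlorophenyl gives a number no lower from compound 2 to compound 4 (the limit leaves the size open), a step whose size cannot be read.

On these data alone, how far compound 4 lies past its limit stays open. Also open, as far as these compounds go, is whether methyl, a longer chain or an amine on the sulfur would keep the number this high.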